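The source may hold more compounds than are shown below. What is called first, only, known or untested is meant among the compounds shown, and "the series" means these compounds.

Measured so far in a functional assay on A2780 cells (Homo sapiens) for inhibition, read by sulforhodamine B assay, with a stated time of 72 h (on this read-out higher numbers stand for weaker inhibition and lower numbers for stronger inhibition), as follows:
- Compound 1 `O=C(NCc1ccc(S(=O)(=O)c2ccccc2)cc1)c1nc2ccncc2s1` gives > 10000 nM as a limit of the assay
- Compound 2 `O=C(NCc1ccc(S(=O)(=O)N2CCCCC2)cc1)c1cnc2nccn2c1` gives 130 nM as a number
- Compound 3 `O=C(NCc1ccc(S(=O)(=O)c2ccccc2)cc1)c1cn2ccnc2cn1` gives > 10000 nM as a limit of the assay

Compound 3 gives > 10000 nM as a limit and not a number. It therefore stands at the limit of > 10000 nM in this assay, at which 2 of the 3 values shown sit, and has no exact place on the scale. Compound 4 `O=C(NCc1ccc(S(=O)(=O)c2ccccc2)cc1)c1cnc2nccn2c1` differs from compound 3 only on the carbonyl carbon, where one fused group replaces another: a group of 9 heavy atoms (6 carbon, 3 nitrogen; one five-membered aromatic ring with 2 hetero atoms, one six-membered aromatic ring with 2 hetero atoms) in place of a group of 9 heavy atoms (6 carbon, 3 nitrogen; one five-membered aromatic ring with 2 hetero atoms, one six-membered aromatic ring with 2 hetero atoms), on a carbonyl carbon and so the atoms stay the same but are joined differently. Going by the values given here, the one measured step at this place is a step that the two limits leave unreadable from compound 1 to compound 3 and it offers no size to carry over. Among the compounds with values here, the group entering in compound 4 is the one carried by compound 2, which gives 130 nM in this assay even though its other end differs. On that value of compound 2 a large gain is expected. The estimated size is an at least 120-fold lower number from compound 3 to compound 4 (2.09 log units; beyond the scatter) in the direction of stronger inhibition. Compound 4 is expected at about 80 nM with an estimated range from 15 nM to 800 nM in this measurement.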

Compound 4, half-maximal inhibitory concentration: 68 nM
Compound 4: the middle estimate sits 1.2-fold (0.07 log units) above what was measured, within the range that was stated.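

In this assay, joining the same atoms differently within the fused group on the carbonyl carbon gives an at least 140-fold lower number from compound 3 to compound 4 (2.16 log units; beyond the scatter), so the arrangement of this group matters and not only its atom count, and replacing the sulfur-containing group of compound 1 with it gives an at least 140-fold lower number from compound 1 to compound 4 (2.16 log units; beyond the scatter). Both of these steps start from a limit and not a number, held by compound 1 and compound 3: the limit of > 10000 nM in this assay, at which 2 of the 4 values shown sit. At the other end of the molecule, phenyl in place of piperidin-1-yl on the sulfonyl sulfur gives a 1.9-fold lower number from compound 2 to compound 4 (0.28 log units; within the scatter), so with this fused group the two cannot be told apart here.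

The compounds shown leave open how a methyl or a fluorine on the fused group, or a morpholin-4-yl on the sulfonyl sulfur, would read in this assay. Also open, going by these compounds, is whether piperidin-1-yl on the sulfonyl sulfur would change anything for the fused groups of compound 1 and compound 3.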